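This account rests on a few compounds, and the source may have more. Where it says the series, first, only, none or still open, it means among the compounds named here.

Measured so far in a functional assay on MDA-MB-231 cells (Homo sapiens) for cytotoxicity, read by ELISA, with a stated time of 2 days; on this read-out lower numbers stand for stronger inhibition and higher numbers for weaker inhibition:

compound 1 `Oc1ccccc1-c1cc(-c2ccccc2)cc(-c2ccccc2O)n1` gives 37300 nM
compound 2 `Oc1ccccc1-c1cc(-c2ccccc2)nc(-c2ccco2)c1` gives 4600 nM
compound 3 `Oc1cccc(-c2cc(-c3ccccc3)nc(-c3cccs3)c2)c1` gives 17700 nM

Compound 3 holds the middle place among these three numbers. Compound 1 stands above it and compound 2 below it, and both gaps lie beyond the usual scatter of repeated measurements.

The next compound, compound 4 `Oc1cccc(-c2cc(-c3ccccc3)nc(-c3ccncc3)c2)c1`, carries pyridin-4-yl in place of the thiophen-2-yl of compound 3, on an aromatic carbon next to the ring nitrogen (pyridin-4-yl in place of thiophen-2-yl on an aromatic carbon). For the measured compounds named here, the measured compounds differ from one another in more than one place, so no measured step speaks directly to this exchange. Going by the values given here, the only guide is the spread of values, from compound 2 at 4600 nM to compound 1 at 37300 nM, with compound 3 at 17700 nM inside it. On that basis, only a small move in this assay is expected, slightly toward a lower number and not beyond the scatter. The estimated step is a 1.5-fold lower number from compound 3 to compound 4 (0.17 log units; within the scatter) and carries wide uncertainty. Compound 4 is expected at 12000 nM, with an estimated range from 4000 nM to 35000 nM in this read-out.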

Compound 4, half-maximal inhibitory concentration: 12200 nM
Estimate against measurement, compound 4: 1.0-fold (0.01 log units) below; the range from low to high includes it.
By their numbers in this assay, from the lowest: compound 2; then compounds 4 and 3 (each within the scatter of the next); then compound 1.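

In this assay, for the compounds shown here, the exchange of thiophen-2-yl for pyridin-4-yl on the aromatic carbon next to the ring nitrogen gives a 1.5-fold lower number from compound 3 to compound 4 (0.16 log units; within the scatter), the first step that changes one place only. At this position, meta to a 3-hydroxyphenyl group and meta to a phenyl group, the read-out does not separate a five-membered aromatic ring with a sulfur hetero atom from a six-membered aromatic ring with a nitrogen hetero atom, even though the entering group has 6 heavy atoms and the leaving group 5. Nothing measured here bears on the cause of this result.

The compounds shown leave open whether this position accepts anything other than an aromatic ring, such as an amine, a carboxylic acid or a longer alkyl chain in place of the pyridin-4-yl. On these data alone, with a single step in hand, it also remains open whether the same exchange would read the same way if the hydroxyl group sat elsewhere on the hydroxyphenyl ring or if the phenyl group were replaced.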